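Benzyl in place of sec-butyl on the aromatic nitrogen

The compounds below may be only part of what the source reports. "The series", "measured", "known", "first", "only" and "open" are said of these compounds alone.

Three analogues of the shared core have been run in an in vitro ADME assay on microsomes from liver (Homo sapiens) for metabolic stability, tested at 5 uM; a lower number here means that the compound disappears faster, a higher number that the compound lasts longer. Compound 1 `CS(=O)(=O)Nc1ccc2c(c1)S(=O)(=O)N=C(c1c(O)c(-c3ccc(Cl)s3)nn(CCC3CC3)c1=O)N2` reaches the limit of the assay, reported as > 1 h. Compound 2 `CC(C)=Cc1nn(CCC(C)C)c(=O)c(C2=NS(=O)(=O)c3cc(NS(C)(=O)=O)ccc3N2)c1O` gives 0.55 h. Compound 3 `CCC(C)n1nc(-c2cccs2)c(O)c(C2=NS(=O)(=O)c3cc(NS(C)(=O)=O)ccc3N2)c1=O` also sits at the limit, with > 1 h. Compound 3 thus stands at the limit of > 1 h in this assay, at which 2 of the 3 values shown sit, among the longer-lived members, without a number of its own. Compound 4 `CS(=O)(=O)Nc1ccc2c(c1)S(=O)(=O)N=C(c1c(O)c(-c3cccs3)nn(Cc3ccccc3)c1=O)N2` has not yet been run in this assay. It differs from compound 3 in one place: benzyl in place of sec-butyl on an aromatic nitrogen. Going by the values given here, no step between measured compounds touches this position, so nothing in the set points in a direction. Compound 4 is expected to sit near compound 3, a step of an at least 1.1-fold lower number from compound 3 to compound 4 (0.04 log units; that floor lies within the scatter) that stays within the scatter. The estimate for compound 4 is 0.9 h, with a range from 0.4 h to 1.8 h.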

Compound 4, half-life: > 1 h
Compound 4 was reported as a limit; the forecaster's own chance of this, stated with the estimate: 40%; middle value at least 1.1-fold (0.04 log units) from the limit.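

Compound 3 and compound 4 both give only a limit in this assay, so no step can be read between them: the limit of > 1 h in this assay, at which 3 of the 4 values shown sit.

The compounds shown leave open whether benzyl or sec-butyl on the aromatic nitrogen gives the longer half-life.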